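Chloro to Hydroxy: What to Expect for Compound 3

The source may hold more compounds than are shown below. What is called first, only, known or untested is meant among the compounds shown, and "the series" means these compounds.

Measured so far:
compound 1 `O=C(N/N=C/c1ccccc1Cl)Nc1ccc(Br)cc1`: 300 mg/kg
compound 2 `CCOc1ccc(NC(=O)N/N=C/c2ccccc2Cl)cc1`: 100 mg/kg

In a functional assay on the whole organism with Mus musculus as the target, in the maximal electroshock model, with a stated time of 0.5 h (on this read-out lower numbers stand for an effect already at smaller amounts and higher numbers for an effect only at larger amounts of compound), compound 1 gives 300 mg/kg, while compound 2 gives 100 mg/kg. Compound 2 thus has the lowest of the two numbers measured, reached through a 3.0-fold lower number from compound 1 to compound 2 (0.48 log units; beyond the scatter), a change of ethoxy in place of bromo on an aromatic carbon.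

Compound 3 `CCOc1ccc(NC(=O)N/N=C/c2ccccc2O)cc1` has not yet been measured. It differs from compound 2 by hydroxy in place of chloro on an aromatic carbon. Within the data shown here, the one measured step, from compound 1 to compound 2, touches a different part of the shared core, so no measured step bears on a hydroxy in place of chloro; the effect of this change is an open question.

With nothing to point either way, compound 3 is expected to stay near compound 2, giving an estimated no change at the digits printed from compound 2 to compound 3 (within the scatter) that is not beyond the scatter. The estimated value for compound 3 is 100 mg/kg, within a range from 30 mg/kg to 300 mg/kg.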

Compound 3, minimum effective dose: 300 mg/kg
For compound 3 the middle estimate is 3.0-fold (0.48 log units) below the measured one, and the stated range covers the measured number.
By their numbers in this assay, from the lowest: compound 2; then compounds 1 and 3 (each within the scatter of the next).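

In this assay, the change from chloro to hydroxy gives a 3.0-fold higher number from compound 2 to compound 3 (0.48 log units; beyond the scatter) and so moves the dose needed by more than the usual scatter. This shows that the group on this aromatic carbon, ortho to a large group, matters for the effect in mice, and that 2-hydroxyphenyl is not an equal swap for 2-chlorophenyl here. The earlier step could not show this, as it changed a different part of the shared core, and no measurement at hand explains why the number rises here.

On these data alone, whether an amine or a methyl group in this same place would behave more like chloro or more like hydroxy remains open. As far as these compounds go, it is also open whether this change would have a similar size in the core of compound 1, where bromo stands in place of ethoxy.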